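Acetal side chain variation on the shared core

The compounds below may be only part of what the source reports. "The series", "measured", "known", "first", "only" and "open" are said of these compounds alone.

Two measured compounds carry a sulfur-linked side chain on the shared core. In an assay on microsomes from liver for inhibition of sterol O-acyltransferase 1 (Rattus norvegicus) (on this read-out lower numbers stand for stronger inhibition and higher numbers for weaker inhibition), compound 1 `C[C@@]1(O)CC(=O)OC(CSc2nc(-c3ccccc3)c(-c3ccccc3)[nH]2)C1` gives 170 nM. In this assay compound 2 `COC(CSc1nc(-c2ccccc2)c(-c2ccccc2)[nH]1)OC` gives 580 nM. For the measured compounds named here, the single measured step, a 3.4-fold higher number from compound 1 to compound 2 (0.53 log units; beyond the scatter), moves the number upward, so compound 2 stands as the highest of the two numbers so far, with compound 1 as its nearest neighbour.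

Compound 3 `CCOC(CCSc1nc(-c2ccccc2)c(-c2ccccc2)[nH]1)OCC` is not yet measured. It differs from compound 2 by 2,2-diethoxyethyl in place of dimethoxymethyl on a saturated chain carbon bound to a sulfur; cut one bond further out, the same difference reads 2,2-dimethoxyethyl to 3,3-diethoxypropyl. Going by the values given here, the only step touching this position is a 3.4-fold higher number from compound 1 to compound 2 (0.53 log units; beyond the scatter), a modest move for an exchange of a ring for an open chain. The present change stays within the open-chain arrangement of compound 2, so no move beyond the scatter is expected in this assay, in either direction. Compound 3 is therefore estimated at 400 nM, with a range of 150 nM to 1200 nM. That estimate means an expected step of a 1.5-fold lower number from compound 2 to compound 3 (0.16 log units; within the scatter), within the scatter.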

Compound 3, half-maximal inhibitory concentration: 69 nM
The estimate for compound 3 lay 5.8-fold (0.76 log units) above the measured number, outside the stated range (below it).
By their numbers in this assay, from the lowest: compound 3; then compound 1; then compound 2.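

The position on the saturated chain carbon bound to a sulfur responds strongly within the open-chain series in this assay: 2,2-diethoxyethyl in place of dimethoxymethyl gives an 8.4-fold lower number from compound 2 to compound 3 (0.92 log units; beyond the scatter), so a change that keeps the side chain free of any ring and leaves its net charge unaltered can still move the number well beyond the scatter. The ring in the side chain of compound 1 is also not needed for the lowest number seen so far, since a 2.5-fold lower number from compound 1 to compound 3 (0.39 log units; beyond the scatter) leaves compound 3, with no ring in that group, lowest of the three. No measurement at hand bears on the origin of either step.

The step from compound 2 to compound 3 changes chain length and the groups on the acetal oxygens together, so the compounds shown leave the share of each unresolved; the 3,3-dimethoxypropyl and 2,2-diethoxyethyl side chains, read one against the other and against compound 3, would separate the two. Also open, from the compounds shown here alone, is whether the trend continues to a longer chain such as 4,4-diethoxybutyl, and how an amine or a carboxylic acid at the end of the side chain would compare with the acetal.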